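The source may report more compounds than this note shows. Statements on the series, on what has been measured and on what is new or still open speak of the compounds shown alone.

Within the data shown here, compound 3 `COc1cc2c(Oc3ccc(NC(=O)c4cc(-c5ccccc5)ccn4)cc3F)ccnc2cc1OCCCN1CCCC1` sits in the middle of the three numbers so far: in a functional assay on HT-29 cells (Homo sapiens) for cytotoxicity, read by MTT assay, with a stated time of 72 h (a lower number here means a stronger inhibitor, a higher number a weaker inhibitor), compound 3 gives 120 nM, while compound 1 `COc1cc2c(Oc3ccc(NC(=O)c4cc(-c5ccccc5)ccn4)cc3F)ccnc2cc1OCCCN1CCN(C)CC1` gives 82 nM and compound 2 `COc1cc2c(Oc3ccc(NC(=O)c4cc(-c5ccc(C(F)(F)F)cc5)ccn4)cc3F)ccnc2cc1OCCCN1CCCCC1` gives 230 nM. Among the measured compounds shown here, the one single-point step measured, a 1.5-fold higher number from compound 1 to compound 3 (0.17 log units; within the scatter), concerns the amine at the end of the chain and not the aryl group on the pyridine.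

Compound 4 `COc1ccc(-c2ccnc(C(=O)Nc3ccc(Oc4ccnc5cc(OCCCN6CCCC6)c(OC)cc45)c(F)c3)c2)c(OC)c1` differs from compound 3 only in that aryl group: 2,4-dimethoxyphenyl in place of phenyl on an aromatic carbon. For the measured compounds named here, no measured pair isolates a change at this position. Compound 2 carries a substituted phenyl there, but it also carries a different amine on the chain, so its number cannot be read as a step from compound 3; its value and that of compound 3 lie within the scatter of each other in any case. With the three values spanning so narrow a band, the expectation for compound 4 is no step beyond the scatter, a 1.3-fold higher number from compound 3 to compound 4 (0.10 log units; within the scatter). Compound 4 is therefore estimated at 150 nM in this assay, within 50 nM to 450 nM.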

Compound 4, half-maximal inhibitory concentration: 630 nM
Estimate against measurement, compound 4: 4.2-fold (0.62 log units) below, outside the stated range (above it).
By their numbers in this assay, from the lowest: compounds 1, 3 and 2 (each within the scatter of the next, the first and the last beyond it); then compound 4.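

Among these compounds, the aryl group on the aromatic carbon opposite the ring nitrogen is not a silent position in this assay: 2,4-dimethoxyphenyl in place of phenyl gives a 5.3-fold higher number from compound 3 to compound 4 (0.72 log units; beyond the scatter) and is the first single-point change beyond the scatter. The only earlier step changed the amine at the end of the chain and stayed within the scatter, so this position has now shown a response that the amine change did not, here towards a weaker inhibitor. Nothing at hand accounts for this step.

From the compounds shown here alone, the two methoxy groups enter together, so 2-methoxyphenyl and 4-methoxyphenyl remain open as separate cases at this position. Also open, going by these compounds, is whether 2,4-dimethoxyphenyl gives a similar step with 4-methylpiperazin-1-yl on the chain in place of pyrrolidin-1-yl.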